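This account rests on a few compounds, and the source may have more. Where it says the series, first, only, none or still open, it means among the compounds named here.

Among the measured compounds shown here, compound 2, `CCC(=O)NCc1cc(OC)ccc1F`, is the one with the higher of the two numbers so far in an assay on isolated protein for agonist activity at melatonin receptor type 1C (Xenopus laevis), read by spectrophotometry; a higher number here means that more compound is needed for the effect, a lower number that less compound is needed: compound 2 gives 2400 nM. For the measured compounds named here, its only neighbour is compound 1, `COc1ccc(F)c(CNC(C)=O)c1`, and in this assay compound 1 gives 1950 nM; the two values lie within the scatter of each other, so neither can be called the more potent.

Going by the values given here, the one measured step, a 1.2-fold higher number from compound 1 to compound 2 (0.09 log units; within the scatter), came from a methyl in place of hydrogen on a saturated chain carbon bound to a carbonyl carbon, that is, from lengthening the chain on the amide by one carbon.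

Compound 3, `CCCC(=O)NCc1cc(OC)ccc1F`, repeats that kind of change one bond further out: methyl in place of hydrogen on a saturated chain carbon, two bonds along the chain from a carbonyl carbon.

The step that bears on this is the earlier chain extension, and it moved the number by a 1.2-fold higher number from compound 1 to compound 2 (0.09 log units; within the scatter), nothing beyond the scatter. On that basis adding one more carbon to the chain is expected to leave this assay essentially unchanged, a step of a 1.0-fold higher number from compound 2 to compound 3 (0.02 log units; within the scatter). Compound 3 is therefore estimated at 2500 nM, with a likely range from 1100 nM to 5500 nM.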

Compound 3, half-maximal effective concentration: 1350 nM
Compound 3: middle estimate off by 1.9-fold (0.27 log units), on the high side; measured number inside the range.
By their numbers in this assay, from the lowest: compounds 3, 1 and 2 (each within the scatter of the next).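

In this assay, the methyl added two bonds along the chain from a carbonyl carbon gives a 1.8-fold lower number from compound 2 to compound 3 (0.25 log units; within the scatter), and the ethyl in place of hydrogen on the saturated chain carbon bound to a carbonyl carbon gives a 1.4-fold lower number from compound 1 to compound 3 (0.16 log units; within the scatter). Neither step lies beyond the scatter, so the further position also accepts an added methyl without a change that can be told from ordinary repeat variation, and the series now spans methyl, ethyl and propyl on the carbonyl with no trend that these numbers can support. Nothing available here speaks to what lies behind this result.

Still open, as far as these compounds go, is whether a longer chain, such as butyl or pentyl, or a branched chain such as isopropyl, would also stay within the scatter of these three compounds. Also open is what a ring such as cyclopropyl, or an amine or a carboxylic acid at the end of the chain, would do to the number, since the compounds shown carry only unbranched carbon chains at this place.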